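The source may report more compounds than this note shows. Statements on the series, on what has been measured and on what is new or still open speak of the compounds shown alone.

Measured so far in a functional assay on A549 cells (Homo sapiens) for cytotoxicity, read by MTT assay, with a stated time of 48 h; on this read-out lower numbers stand for stronger inhibition and higher numbers for weaker inhibition:
- compound 1 `Cc1ccc(-c2csc(NC(=O)COc3ccc(Cl)c(C)c3)n2)cc1` gives 44900 nM
- compound 2 `Cc1ccc(-c2csc(NC(=O)COc3ccc(F)cc3F)n2)cc1` gives 13900 nM
- compound 3 `Cc1ccc(-c2csc(NC(=O)COc3ccc(F)cc3)n2)cc1` gives 19300 nM

Compound 3 stands second highest of the three numbers. Its nearest neighbour is compound 2, from which it is separated only within the scatter (a 1.4-fold higher number from compound 2 to compound 3 (0.14 log units; within the scatter)); compound 1 lies further off (a 2.3-fold lower number from compound 1 to compound 3 (0.37 log units; beyond the scatter)). The two changes among the measured compounds both sit on the phenoxy side: a 3.2-fold lower number from compound 1 to compound 2 (0.51 log units; beyond the scatter) and a 2.3-fold lower number from compound 1 to compound 3 (0.37 log units; beyond the scatter).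

Compound 4 `O=C(COc1ccc(F)cc1)Nc1nc(-c2ccc(Cl)cc2)cs1` is not yet measured. It differs from compound 3 by chloro in place of methyl on an aromatic carbon, which, read one bond further out, is 4-methylphenyl to 4-chlorophenyl. For the measured compounds named here, none of the measured steps touches this ring; every measured change lies on the oxygen-linked aryl group. Going by the values given here, there is therefore no step that bears on this change, and the default expectation is a step of no size beyond the scatter in this assay , i.e. a 1.0-fold lower number from compound 3 to compound 4 (0.01 log units; within the scatter) is expected to be small. Compound 4 is estimated at 19000 nM, with a range of 7000 nM to 50000 nM.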

Compound 4, half-maximal inhibitory concentration: 36500 nM
Estimate against measurement, compound 4: 1.9-fold (0.28 log units) below; the range from low to high includes it.
By their numbers in this assay, from the lowest: compounds 2, 3, 4 and 1 (each within the scatter of the next, the first and the last beyond it).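

For the compounds shown here, this is the first reading on the 4-methylphenyl side of the series, as all earlier changes lay on the oxygen-linked aryl group. In this assay, chloro in place of methyl, para to a large group, gives a 1.9-fold higher number from compound 3 to compound 4 (0.28 log units; within the scatter), so this swap cannot be told apart from repeat-measurement noise, and the series shows no effect of it at this position. No measurement available explains this result.

The compounds shown leave open whether an amine, a carboxylic acid or a methoxy group at this place would move the number beyond the scatter. They also leave open whether chloro for methyl reads the same with the 2,4-difluorophenyl or 4-chloro-3-methylphenyl group on the oxygen.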